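Methoxy on the Pendant Ring, Tried Again on a Fluorinated Core

The source may report more compounds than this note shows. Statements on the series, on what has been measured and on what is new or still open speak of the compounds shown alone.

Compound 1 `COc1cc2c(Oc3ccc(NC(=O)c4cc(-c5ccccc5)nc5ccccc45)cc3F)ccnc2cc1OCCCN1CCCCC1`: 15 nM
Compound 2 `COc1ccc(-c2cc(C(=O)Nc3ccc(Oc4ccnc5cc(OCCCN6CCCCC6)c(OC)cc45)c(F)c3)c3ccccc3n2)cc1`: 210 nM
Compound 3 `COc1cc2c(Oc3ccc(NC(=O)c4cc(-c5ccccc5)nc5ccc(F)cc45)cc3F)ccnc2cc1OCCCN1CCCCC1`: 30 nM

All three were measured in a functional assay on MKN-45 cells (Homo sapiens) for cytotoxicity, read by MTT assay, with a stated time of 72 h; a higher number here means a weaker inhibitor, a lower number a stronger inhibitor. Compound 1 and compound 3 share almost everything; the difference is fluoro in place of hydrogen on an aromatic carbon, and the step is a 2.0-fold higher number from compound 1 to compound 3 (0.30 log units; within the scatter), so these two cannot be told apart by this assay. Compound 2 differs from compound 1 by methoxy in place of hydrogen on an aromatic carbon, and here the step is a 14-fold higher number from compound 1 to compound 2 (1.15 log units; beyond the scatter), a clear loss of potency.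

Compound 4 `COc1cccc(-c2cc(C(=O)Nc3ccc(Oc4ccnc5cc(OCCCN6CCCCC6)c(OC)cc45)c(F)c3)c3cc(F)ccc3n2)c1` has not yet been measured. It differs from compound 3 by methoxy in place of hydrogen on an aromatic carbon. For the measured compounds named here, this is the same kind of change as the one from compound 1 to compound 2, but not the same: in compound 2 the methoxy sits para to a large group, in compound 4 it sits meta to a large group. The two cores differ by fluoro in place of hydrogen on an aromatic carbon, a difference that left the number nearly unchanged.

Going by the values given here, only one earlier methoxy step is known, and it was large. Since the new methoxy is placed differently, a somewhat smaller step in the same direction is expected, estimated as a 5.0-fold higher number from compound 3 to compound 4 (0.70 log units; beyond the scatter). Compound 4 is therefore estimated at 150 nM, with the likely range running from 40 nM to 600 nM.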

Compound 4, half-maximal inhibitory concentration: 690 nM
Estimate against measurement, compound 4: 4.6-fold (0.66 log units) below, outside the stated range (above it).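

In this assay, replacing phenyl with 3-methoxyphenyl on the fluorinated core gives a 23-fold higher number from compound 3 to compound 4 (1.36 log units; beyond the scatter), a clear loss of potency. The loss seen on the first core therefore appears again on the second, and its size cannot be told apart between the two: the same change on two cores in this assay, a 14-fold higher number (1.15 log units; beyond the scatter) from compound 1 to compound 2 and a 23-fold higher number (1.36 log units; beyond the scatter) from compound 3 to compound 4, 1.6-fold (0.22 log units) apart, within the scatter of two such steps. For the compounds shown here, this shows that, for these two cores, which differ only by one fluoro, adding a methoxy to the pendant ring was costly both times, but it does not show that the cost would hold on a core that differs more, and with only two examples it does not separate any influence of the core from that of the methoxy's place, since in compound 4 the methoxy sits meta to a large group and in compound 2 it sits elsewhere.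

The compounds shown leave open how the core of compound 1 would respond to a methoxy in the place it holds in compound 4, which would compare the two cores directly. They also leave open whether a smaller group in that place, such as a methyl, a chloro or a hydroxy, would bring the same loss or a smaller one.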